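This account rests on a few compounds, and the source may have more. Where it says the series, first, only, none or still open, it means among the compounds named here.

Series notes, cytotoxicity. Among the measured compounds shown here, compound 1 `Cc1nc2c(c(-c3cc(F)c4c(c3C)CCCO4)c1[C@H](OC(C)(C)C)C(=O)O)CN(CC1CC1c1ccccc1)CC2` is one of two compounds measured in an ADME assay on MT2 cells (Homo sapiens) for cytotoxicity, read by XTT assay, with a stated time of 4 days; a higher number here means that more compound is tolerated, a lower number that less compound is tolerated. In this assay compound 1 gives > 40000 nM, which is a limit of the assay rather than a number. Compound 2 `CCCCCN1CCc2nc(C)c(C(OC(C)(C)C)C(=O)O)c(-c3ccc(C)cc3)c2C1` is the other measured member. In this assay compound 2 gives > 40000 nM, again a limit and not a number. Compound 2 therefore stands at the same limit as compound 1; both sit at the limit of > 40000 nM in this assay, at which 2 of the 2 values shown sit, and no numbered step between them can be stated. Compound 3 `Cc1ccc(-c2c3c(nc(C)c2C(OC(C)(C)C)C(=O)O)CCN(C)C3)cc1` is not yet measured in this assay. It differs from compound 2 by hydrogen in place of butyl on a saturated chain carbon bound to an amine nitrogen in a ring. No measured step in this assay is available in the series, so the expectation rests on the two limits shown. The step from compound 2 to compound 3 is expected to be a step that the limit leaves unreadable from compound 2 to compound 3, that is none beyond the scatter. For compound 3 the estimate in this assay is 60000 nM, within a range of 25000 nM to 150000 nM, most likely reported again as a limit.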

Compound 3, half-maximal cytotoxic concentration: > 40000 nM
Compound 3: only a limit was reported; the forecaster's own chance of this, stated with the estimate: 85%; the middle value does not contradict the limit.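

Compound 3 gives > 40000 nM in this assay, which is a limit and not a number, so no step can be read from compound 2 to compound 3: the limit of > 40000 nM in this assay, at which 3 of the 3 values shown sit.

The compounds shown leave open at what concentration any of them becomes cytotoxic, and whether hydrogen in place of butyl alters it.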